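Pyridin-3-yl in place of phenyl on a carbonyl carbon

This account rests on a few compounds, and the source may have more. Where it says the series, first, only, none or still open, it means among the compounds named here.

In an ADME assay on HepG2 2.2.15 cells (Homo sapiens) for cytotoxicity, read by MTT assay (on this read-out lower numbers stand for higher toxicity in this test and higher numbers for lower toxicity in this test), compound 1 (`CC(=O)c1ccc(O[C@@H]2O[C@H](COC(=O)/C=C/c3cccc(F)c3)[C@@H](O)[C@H](O)[C@H]2O)cc1`) gives 828000 nM and compound 2 (`CC(=O)c1ccc(O[C@@H]2O[C@H](COC(=O)c3ccccc3)[C@@H](O)[C@H](O)[C@H]2O)cc1`) gives 1050000 nM, so the two stand level within the scatter. Compound 3 (`CC(=O)c1ccc(O[C@@H]2O[C@H](COC(=O)c3cccnc3)[C@@H](O)[C@H](O)[C@H]2O)cc1`) differs from compound 2 at one place, with pyridin-3-yl in place of phenyl on a carbonyl carbon. For the measured compounds named here, the only measured step at this place, a 1.3-fold higher number from compound 1 to compound 2 (0.10 log units; within the scatter), exchanged 2-(3-fluorophenyl)ethenyl for phenyl and stayed within the scatter. The new change has not been measured, so nothing beyond the scatter is expected in this assay. The expected step is a 1.1-fold lower number from compound 2 to compound 3 (0.02 log units; within the scatter). For compound 3 the estimate is 1000000 nM, with an expected range of 500000 nM to 2000000 nM.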

Compound 3, half-maximal cytotoxic concentration: > 1650000 nM
Compound 3: only a limit was reported; the forecaster's own chance of this, stated with the estimate: 20%; middle value at least 1.6-fold (0.21 log units) from the limit.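

The reading for compound 3 in this assay is a limit and not a number: the limit of > 1650000 nM in this assay, at which 1 of the 3 values shown sits. At this position, on a carbonyl carbon, pyridin-3-yl in place of phenyl gives an at least 1.5-fold higher number from compound 2 to compound 3 (0.19 log units; that floor lies within the scatter), and in place of 2-(3-fluorophenyl)ethenyl it gives an at least 1.9-fold higher number from compound 1 to compound 3 (0.29 log units; that floor lies within the scatter). For the compounds shown here, both floors lie within the scatter, so this position so far tolerates a ring nitrogen with no sign of a lower number, while the true size of either step stays unknown. Still open, from the compounds shown here alone, is whether an amine or a carboxylic acid on the aromatic ring at this position would lower the number in this assay.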